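Cyclopropyl in place of isopropoxy: clearance notes

The compounds below may be only part of what the source reports. "The series", "measured", "known", "first", "only" and "open" are said of these compounds alone.

In a toxicity assay on microsomes from liver (Homo sapiens) for metabolic stability, read by LC-MS, using NADPH, tested at 1 uM (on this read-out lower numbers stand for slow clearance and higher numbers for fast clearance), compound 1 `CCOc1ncc(-c2nc(C(F)(F)F)sc2N2CCN(C(=O)Cn3ccc(C(F)(F)F)n3)[C@H](C)C2)cn1` gives 20 mL.min-1.g-1 and compound 2 `Cc1nc(C)n(CC(=O)N2CCN(c3sc(C(F)(F)F)nc3-c3cnc(OC(C)C)nc3)C[C@H]2C)n1` gives 16 mL.min-1.g-1, two values within the scatter of each other. Compound 3 `Cc1nc(C)n(CC(=O)N2CCN(c3sc(C(F)(F)F)nc3-c3cnc(C4CC4)nc3)C[C@H]2C)n1` has cyclopropyl in place of isopropoxy on an aromatic carbon of compound 2 (cyclopropyl in place of isopropoxy on an aromatic carbon). Going by the values given here, no measured pair shows this change, so the expectation rests on compound 2 at 16 mL.min-1.g-1 and no shift beyond the scatter is anticipated. The expected step of a 1.1-fold lower number from compound 2 to compound 3 (0.06 log units; within the scatter) is small and slightly downward in this assay. For compound 3, the estimated value is 14 mL.min-1.g-1, with an expected range of 7 mL.min-1.g-1 to 28 mL.min-1.g-1.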

Compound 3, intrinsic clearance in microsomes: < 10 mL.min-1.g-1
Compound 3 ended at the assay's limit; the forecaster's own chance of this, stated with the estimate: 3%; at least 1.4-fold (0.14 log units) between middle value and limit.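

At the position between two ring nitrogen atoms, cyclopropyl in place of isopropoxy gives an at least 1.6-fold lower number from compound 2 to compound 3 (0.20 log units; that floor lies within the scatter) in this assay. Compound 3 reads as a limit of the assay, not a number: the limit of < 10 mL.min-1.g-1 in this assay, at which 1 of the 3 values shown sits. Isopropoxy can therefore give way to cyclopropyl here with no rise in clearance, though only the floor of the step can be read.

An amine or a longer chain at this position remains untested in the compounds shown. On these data alone, whether the change carries over to the side chain of compound 1 also remains open.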